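Cyclopentyl to cyclohexyl on the aminonitrogen of compound 3

This account rests on a few compounds, and the source may have more. Where it says the series, first, only, none or still open, it means among the compounds named here.

Three compounds of the series carry numbers in an assay on HT-29 cells for inhibition of Serine-protein kinase ATM (Homo sapiens), read by fluorescence, with a stated time of 1 h; on this read-out lower numbers stand for stronger inhibition and higher numbers for weaker inhibition. Compound 1 `C[C@@H](Nc1c(C(N)=O)cnc2ccc(C#N)cc12)c1ccc(Cl)cc1` gives 14400 nM. Compound 2 `CCC(CC)CNc1c(C(N)=O)cnc2ccc(-c3cccnc3)cc12` gives 73 nM. Compound 3 `NC(=O)c1cnc2ccc(-c3cccnc3)cc2c1NC1CCCC1` gives 137 nM. Among these, compound 3 stands second highest: its nearest neighbour is compound 2, at a gap that lies within the scatter, and its furthest is compound 1, whose number lies well beyond the scatter above it. Compound 1 also differs from compound 3 in more than one place, so only the two values themselves can be compared there.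

Compound 4 `NC(=O)c1cnc2ccc(-c3cccnc3)cc2c1NC1CCCCC1` has not been measured. It differs from compound 3 in one place: cyclohexyl in place of cyclopentyl on a nitrogen on an aromatic ring. Among the compounds with values here, the single measured step that bears on a change at this nitrogen is a 1.9-fold higher number from compound 2 to compound 3 (0.27 log units; within the scatter), where a branched chain and a five-membered ring gave numbers within the scatter of one another. Nothing measured separates ring sizes at this position. On that basis the step from compound 3 to compound 4 is expected to be a 1.1-fold lower number from compound 3 to compound 4 (0.06 log units; within the scatter), with no direction claimed beyond the scatter. Compound 4 is therefore estimated at 120 nM, with a range from 45 nM to 320 nM.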

Compound 4, half-maximal inhibitory concentration: 132 nM
Compound 4: middle estimate off by 1.1-fold (0.04 log units), on the low side, within the range that was stated.
By their numbers in this assay, from the lowest: compounds 2, 4 and 3 (each within the scatter of the next); then compound 1.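

In this assay, within the data shown here, the first direct comparison of ring sizes on this nitrogen gives a 1.0-fold lower number from compound 3 to compound 4 (0.02 log units; within the scatter), so cyclopentyl and cyclohexyl are not separated at this position. The open-chain comparison gives a 1.8-fold higher number from compound 2 to compound 4 (0.26 log units; within the scatter), which places cyclohexyl within the scatter of 2-ethylbutyl as well, so compounds 2, 3 and 4 form a group of three substituents with numbers that cannot be told apart, one branched chain and two carbon rings. No supporting measurement is available to account for this agreement.

Going by these compounds, all three of these substituents consist of carbon only, so it remains open whether the same agreement would hold for a smaller ring such as cyclopropyl, a larger ring such as cycloheptyl, or a ring carrying an amine or a hydroxyl group, such as piperidinyl or hydroxycyclohexyl. Compound 1 differs from these compounds in more than one place, so its much higher number cannot be assigned to the group on this nitrogen, and the contribution of that group remains unresolved.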